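This account rests on a few compounds, and the source may have more. Where it says the series, first, only, none or still open, it means among the compounds named here.

Measured so far in a functional assay on the whole organism (Tail, strain ICR) with Mus musculus as the target, in the tail flick test, with a stated time of 60 min, at a dose of 25 umol/kg by the oral route; a lower number here means a weaker effect, a higher number a stronger effect of the compound at the dose given:
compound 1, `CC[C@H](C)[C@H](NC(=O)CN(c1nc(Cl)nc2[nH]cnc12)C1CC1)C(=O)OCc1ccccc1`: 40.6%
compound 2, `CC(C)C[C@H](NC(=O)CN(c1nc(Cl)nc2[nH]cnc12)C1CC1)C(=O)OCc1ccccc1`: 27.3%

Within the data shown here, compound 2 holds the lower of the two numbers; the one measured step, a number 13.3 percentage points lower from compound 1 to compound 2 (beyond the scatter), is beyond the scatter and modest in size. Compound 3, `C[C@H](NC(=O)CN(c1nc(Cl)nc2[nH]cnc12)C1CC1)C(=O)OCc1ccccc1`, differs from compound 2 by hydrogen in place of isopropyl on a saturated chain carbon, two bonds along the chain from an amide-type nitrogen and a carbonyl carbon. Among the measured compounds shown here, the only step that bears on this change is that same a number 13.3 percentage points lower from compound 1 to compound 2 (beyond the scatter): it alters the substituent at the same saturated chain carbon, and in that single case the swap lowered the read-out. For the measured compounds named here, no measured pair covers removing the branched chain altogether, so the direction rests on one step and the uncertainty is wide. A further modest fall, or no step beyond the scatter, seems most likely; a rise is not ruled out. For compound 3 the expected step is a number 8.3 percentage points lower from compound 2 to compound 3 (within the scatter). Compound 3 is thus estimated at 19% in this assay, with a range from 4% to 38%.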

Compound 3, a percentage reported as activity, at one dose (the size of the read-out at that dose, not a potency): 64.3%
Compound 3: the middle estimate sits 45.3 percentage points below what was measured; the measured number lies above the stated range.
By their numbers in this assay, from the lowest: compound 2; then compound 1; then compound 3.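

In this assay the substituent on this saturated chain carbon matters more than compound 1 and compound 2 alone could show: the change of isobutyl to methyl gives a number 37 percentage points higher from compound 2 to compound 3 (beyond the scatter), and methyl in place of sec-butyl gives a number 23.7 percentage points higher from compound 1 to compound 3 (beyond the scatter). The earlier step compared only two branched chains, whereas compound 3 now places the smallest of the three groups at the top of the series, with both steps beyond the scatter. No evidence is available that accounts for this rise.

As far as these compounds go, it remains open whether a straight propyl chain would read with methyl or with the two branched chains. From the compounds shown here alone, how an amine or a carboxylic acid on this carbon would read also remains open.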